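Thiazolyl amide in place of chlorophenyl on a cinnamate ester

The source may report more compounds than this note shows. Statements on the series, on what has been measured and on what is new or still open speak of the compounds shown alone.

The compounds measured so far:
Compound 1, `COCOc1cc(/C=C/C(=O)OCC(=O)NCc2ccco2)ccc1OCc1ccccc1`: in a functional assay on CNE cells (Homo sapiens) for cytotoxicity, read by MTT assay, with a stated time of 72 h (on this read-out lower numbers stand for stronger inhibition and higher numbers for weaker inhibition), compound 1 gives > 200000 nM, a limit of the assay.
Compound 2, `COCOc1cc(/C=C/C(=O)OCC(=O)Nc2ccc(Cl)cc2)ccc1OCc1ccccc1`: in this assay compound 2 gives > 200000 nM, a limit of the assay.
Compound 3, `CCOc1ccc(COc2c(OC)cc(/C=C/C(=O)N3CCN(Cc4ccc(Cl)c(Cl)c4)CC3)cc2OC)cc1`: in this assay compound 3 gives > 200000 nM, a limit of the assay.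

Compound 2 therefore stands at the limit of this assay, and so do the two other values shown, as the limit of > 200000 nM in this assay, at which 3 of the 3 values shown sit, states. Among the compounds with values here, the only step between measured compounds, a step that the two limits leave unreadable from compound 1 to compound 2, cannot be read, since both of its ends are limits.

Compound 4, `COCOc1cc(/C=C/C(=O)OCC(=O)Nc2nccs2)ccc1OCc1ccccc1`, is still to be measured. It differs from compound 2 by 1,3-thiazol-2-yl in place of 4-chlorophenyl on an amide-type nitrogen. Within the data shown here, no measured step bears on this change directly, and the one step available is unreadable. Among the measured compounds shown here, with every value so far sitting at the limit, no shift beyond the scatter is expected from compound 2 to compound 4 in this assay, and the expected step is a step that the limit leaves unreadable from compound 2 to compound 4. Compound 4 is estimated to give 250000 nM in this assay, within the range 100000 nM to 1000000 nM, most likely again reported only as a limit.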

Compound 4, half-maximal inhibitory concentration: > 200000 nM
Compound 4 gave a limit, no number (the forecaster's own chance of this, stated with the estimate: 85%); the middle value lies beyond the limit too.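

Compound 4 gives only a limit, as do compound 1 and compound 2, so the steps linking compound 4 to compound 1 and compound 2 cannot be read. All of these results stop at the same point: the limit of > 200000 nM in this assay, at which 4 of the 4 values shown sit.

The compounds shown leave open how the groups on the amide-type nitrogen rank against one another in this assay.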